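Swapping the substituent on the shared core, step by step

The compounds below may be only part of what the source reports. "The series", "measured", "known", "first", "only" and "open" are said of these compounds alone.

Compound 1 `Cc1nn(-c2ncnc3nc[nH]c23)c2c1C(OCc1ccc(Cl)cc1Cl)CC(=O)N2`: 4 nM
Compound 2 `Cc1nn(-c2ncnc3nc[nH]c23)c2c1C(c1ccc(OC(C)C)cc1)CC(=O)N2`: 18 nM
Compound 3 `Cc1nn(-c2ncnc3nc[nH]c23)c2c1C(OCCn1nccc1C)CC(=O)N2`: 10 nM

Three compounds share one core and differ only in the group on a saturated ring carbon. In a functional assay on HEK293 cells for agonist activity at G-protein coupled receptor 39 (Homo sapiens), read by scintillation proximity assay and inositol phosphate accumulation, with a stated time of 75 min, in the presence of a further agent that is not named here (a higher number here means that more compound is needed for the effect, a lower number that less compound is needed), compound 1 gives 4 nM. Compound 3 gives 10 nM, the second highest of the three numbers; it sits close to compound 2, with a 1.8-fold lower number from compound 2 to compound 3 (0.26 log units; within the scatter), and further from compound 1, with a 2.5-fold higher number from compound 1 to compound 3 (0.40 log units; beyond the scatter).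

Compound 4 `Cc1nn(-c2ncnc3nc[nH]c23)c2c1C(C(=O)N(C)c1ccccc1)CC(=O)N2` is not yet measured. It carries a methyl(phenyl)carbamoyl in place of the group of compound 3: a group of 10 heavy atoms (8 carbon, 1 nitrogen, 1 oxygen; one six-membered aromatic ring of carbon only) in place of a group of 9 heavy atoms (6 carbon, 2 nitrogen, 1 oxygen; one five-membered aromatic ring with 2 hetero atoms), on a saturated ring carbon. The step that bears most directly on this is the earlier exchange of a six-membered carbon ring for a five-membered ring with two hetero atoms, a 1.8-fold lower number from compound 2 to compound 3 (0.26 log units; within the scatter), which stayed within the scatter; the two other steps, a 4.5-fold higher number from compound 1 to compound 2 (0.65 log units; beyond the scatter) and a 2.5-fold higher number from compound 1 to compound 3 (0.40 log units; beyond the scatter), were modest. Going by the values given here, the entering group, however, is joined through a carbonyl rather than an oxygen, which none of the measured compounds shows, so the expectation is uncertain. Compound 4 is estimated at 25 nM, between 6 nM and 120 nM, which would mean an expected 2.5-fold higher number from compound 3 to compound 4 (0.40 log units; beyond the scatter).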

Compound 4, half-maximal effective concentration: 32 nM
Compound 4: the middle estimate sits 1.3-fold (0.11 log units) below what was measured, and the stated range covers the measured number.
By their numbers in this assay, from the lowest: compound 1; then compounds 3, 2 and 4 (each within the scatter of the next, the first and the last beyond it).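

Joined to the saturated ring carbon through a carbonyl, methyl(phenyl)carbamoyl still gives an agonist in this assay, and compound 4 cannot be told apart from compound 2, which carries 4-isopropoxyphenyl (a 1.8-fold higher number from compound 2 to compound 4 (0.25 log units; within the scatter)). Against the two groups joined through an oxygen, the exchange does show up, both for the group with the pyrazole ring (a 3.2-fold higher number from compound 3 to compound 4 (0.51 log units; beyond the scatter)) and for (2,4-dichlorobenzyl)oxy (an 8.0-fold higher number from compound 1 to compound 4 (0.90 log units; beyond the scatter)). That last step is the largest seen so far among these four compounds, so the choice of group at this position moves the number measurably, though only modestly.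

Still open, on these data alone, is whether a secondary amide, with a hydrogen in place of the methyl on the nitrogen, or a carboxylic acid on this carbon would come closer to compound 1. No other measurement is available to explain any of these steps.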